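Trimming Two Methyls from a Potent Sulfonamide

A few compounds are considered here, and "the series" means these few. Any claim that something is new, unique, unknown or untested is made for them only; others in the source may bear on it.

Compound 3 `Cc1cc(C)nc(NS(=O)(=O)c2ccc(Nc3nncc4ccccc34)cc2)n1` gives 0.8 nM in a functional assay on NCI-H460 cells (Homo sapiens) for antiproliferative activity, read by sulforhodamine B assay, with a stated time of 72 h (on this read-out higher numbers stand for weaker inhibition and lower numbers for stronger inhibition), the lowest number among the three measured compounds. Compound 2 `C(=C/c1ccccc1)\C(=N\Nc1nncc2ccccc12)c1ccccc1` gives 5.7 nM, and compound 1 `Cc1cc(NS(=O)(=O)c2ccc(Nc3nncc4ccccc34)cc2)no1` gives 28 nM. Within the data shown here, the only measured step that alters the group on the sulfonamide nitrogen is a 35-fold lower number from compound 1 to compound 3 (1.54 log units; beyond the scatter), which shows that this position can carry large effects. Compound 4 `O=S(=O)(Nc1ncccn1)c1ccc(Nc2nncc3ccccc23)cc1` differs from compound 3 by pyrimidin-2-yl in place of 4,6-dimethylpyrimidin-2-yl on a sulfonamide nitrogen. Because the step of a 35-fold lower number from compound 1 to compound 3 (1.54 log units; beyond the scatter) favoured the dimethylpyrimidinyl group so strongly, removing its two methyl groups is expected to cost some potency, though less than a full exchange of ring. The expected step of a 3.8-fold higher number from compound 3 to compound 4 (0.57 log units; beyond the scatter) is a moderate rise in the number. Compound 4 is therefore estimated at 3 nM, with a range from 0.8 nM to 12 nM.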

Compound 4, half-maximal inhibitory concentration: 33 nM
Beside the measured number, compound 4's estimate is 11-fold (1.04 log units) below it; measured number above the stated range.
By their numbers in this assay, from the lowest: compound 3; then compound 2; then compounds 1 and 4 (each within the scatter of the next).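

In this assay the step of a 41-fold higher number from compound 3 to compound 4 (1.62 log units; beyond the scatter) shows that, at the sulfonamide nitrogen, the two methyl groups of 4,6-dimethylpyrimidin-2-yl matter as much as the whole exchange of group seen earlier. The step of a 1.2-fold higher number from compound 1 to compound 4 (0.07 log units; within the scatter) lies within the scatter, so pyrimidin-2-yl and 5-methyl-1,2-oxazol-3-yl cannot be told apart on this read-out. Nothing available explains the size of the methyl effect.

As far as these compounds go, whether a single methyl group on the pyrimidin-2-yl group would be enough remains open. So does whether ethyl, methoxy or an amine could stand in place of the methyl groups.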